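Methoxy Added to the Phenyl Carbamate Selenocyanate

This account rests on a few compounds, and the source may have more. Where it says the series, first, only, none or still open, it means among the compounds named here.

Measured compounds:
- compound 1, `C=CCOC(=O)Nc1ccc([Se]C#N)cc1`: 24500 nM
- compound 2, `N#C[Se]c1ccc(NC(=O)Oc2ccccc2)cc1`: 11700 nM
- compound 3, `CCCCCCOC(=O)Nc1ccc([Se]C#N)cc1`: 10700 nM

The three compounds share a core carrying a selenocyanate group and a carbamate, and differ only in the group on the carbamate oxygen. In a functional assay on HT-29 cells (Homo sapiens) for cytotoxicity, read by MTT assay, with a stated time of 72 h (on this read-out higher numbers stand for weaker inhibition of growth and lower numbers for stronger inhibition of growth), compound 1 gives 24500 nM, compound 2 gives 11700 nM and compound 3 gives 10700 nM. Compound 2 stands second highest of the three; the step of a 2.1-fold lower number from compound 1 to compound 2 (0.32 log units; beyond the scatter) lies beyond the scatter, while the step of a 1.1-fold lower number from compound 2 to compound 3 (0.04 log units; within the scatter) does not, so compound 2 and compound 3 cannot be told apart.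

Compound 4, `COc1ccc(OC(=O)Nc2ccc([Se]C#N)cc2)cc1`, differs from compound 2 by methoxy in place of hydrogen on an aromatic carbon on the six-membered aromatic ring of carbon only. Among the measured compounds shown here, no measured step touches that ring: the steps of a 2.1-fold lower number from compound 1 to compound 2 (0.32 log units; beyond the scatter) and a 2.3-fold lower number from compound 1 to compound 3 (0.36 log units; beyond the scatter) both change the group on the oxygen, and were modest. With nothing that bears directly on the change, the expected step of a 1.1-fold lower number from compound 2 to compound 4 (0.03 log units; within the scatter) is none beyond the scatter. Compound 4 is therefore estimated at 11000 nM, in a range from 4000 nM to 30000 nM.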

Compound 4, concentration for 50% growth inhibition: 13600 nM
Compound 4: the middle estimate sits 1.2-fold (0.09 log units) below what was measured, within the range that was stated.
By their numbers in this assay, from the lowest: compounds 3, 2, 4 and 1 (each within the scatter of the next, the first and the last beyond it).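

Among the compounds shown here, the step of a 1.2-fold higher number from compound 2 to compound 4 (0.07 log units; within the scatter) in this assay is the only reading here from a change on the aromatic ring itself, as the earlier steps all swapped the whole group on the carbamate oxygen. It shows that this ring can carry a methoxy para to a large group with no measurable effect on growth inhibition, since compound 2 and compound 4 cannot be told apart. Nothing available explains why the two read alike.

Going by these compounds, whether the ring behaves the same way with a different group at this place, such as an amine, a carboxylic acid or a chlorine atom, or with methoxy at another place on it, stays open. Also open, on these data alone, is how a chain longer than hexyl on the oxygen would read.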